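The compounds below may be only part of what the source reports. "The series", "measured", "known", "first", "only" and "open" are said of these compounds alone.

The compounds measured so far, each with its value in an assay on CHO cells for displacement of a labelled ligand from adenosine receptor A1 (Homo sapiens), read by scintillation counting, with a stated time of 90 min, tested at 1 uM, in the presence of a further agent that is not named here; on this read-out higher numbers stand for more inhibition at the one concentration tested (going by the name of the read-out) and lower numbers for less inhibition:

compound 1, `CCCn1c(=O)[nH]c2nc(-c3ccc(S(=O)(=O)N4CCN(c5ccc(F)cc5)CC4)cc3)[nH]c2c1=O`, 14%
compound 2, `CCCn1c(=O)[nH]c2nc(-c3ccc(S(=O)(=O)N4CCN(c5ccccc5Br)CC4)cc3)[nH]c2c1=O`, 28%
compound 3, `CCCn1c(=O)[nH]c2nc(-c3ccc(S(=O)(=O)N4CCN(c5ccc(I)cc5)CC4)cc3)[nH]c2c1=O`, 24%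

All three share one core and differ only in the group on the amine nitrogen of the ring. Compound 3 sits with its value between the other two, yet neither gap separates it clearly: a number 4 percentage points lower from compound 2 to compound 3 (within the scatter) and a number 10 percentage points higher from compound 1 to compound 3 (within the scatter). Within the data shown here, the only step that clears the scatter is a number 14 percentage points higher from compound 1 to compound 2 (beyond the scatter).

Compound 4, `CCCn1c(=O)[nH]c2nc(-c3ccc(S(=O)(=O)N4CCN(Cc5ccc(Br)cc5)CC4)cc3)[nH]c2c1=O`, is not yet measured. Against compound 3 the change is 4-bromobenzyl in place of 4-iodophenyl on an amine nitrogen in a ring. Among the measured compounds shown here, no measured step swaps an aryl group on that nitrogen for a benzyl group, so the step of a number 4 percentage points lower from compound 2 to compound 3 (within the scatter), which exchanges one halogenated phenyl for another, is the closest guide, and it lies within the scatter. In this assay compound 4 is therefore expected to give about 22%, within 6% to 38%, meaning a step of a number 2 percentage points lower from compound 3 to compound 4 (within the scatter) that is expected not to exceed the scatter.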

Compound 4, a percentage reported as inhibition, at one concentration (the size of the read-out at that concentration, not a potency): 31%
Compound 4: the middle estimate sits 9 percentage points below what was measured, and the stated range covers the measured number.
By their numbers in this assay, from the lowest: compounds 1, 3, 2 and 4 (each within the scatter of the next, the first and the last beyond it).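

In this assay, a benzyl group on the amine nitrogen of the ring reads much like a halogenated phenyl group there, with 4-bromobenzyl giving a number 7 percentage points higher from compound 3 to compound 4 (within the scatter) and a number 3 percentage points higher from compound 2 to compound 4 (within the scatter). Against 4-fluorophenyl the same kind of exchange gives a number 17 percentage points higher from compound 1 to compound 4 (beyond the scatter), so both steps that clear the scatter now start from compound 1, although compound 3 goes against a clean split by staying within the scatter of compound 1. Nothing available explains why this nitrogen accepts the benzyl group.

As far as these compounds go, whether the bromine matters on the benzyl group remains open, as does the effect of moving it to another place on that ring. From the compounds shown here alone, it is also open how an unsubstituted benzyl, a longer phenethyl chain, or a benzyl carrying a carboxylic acid or an amine would read at this nitrogen.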